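From Trifluoromethyl to Nitro: Expecting Compound 4's Growth Inhibition

The source may hold more compounds than are shown below. What is called first, only, known or untested is meant among the compounds shown, and "the series" means these compounds.

Of the compounds shown here, three have so far been tested in a functional assay on A2780 cells (Homo sapiens) for inhibition, with a stated time of 72 h, tested at 10 uM; on this read-out higher numbers stand for more inhibition of growth at the one concentration tested and lower numbers for less inhibition of growth. Compound 1 `CC1(C)CCOc2ccc(NC(=S)Nc3ccc(OC(F)(F)F)cc3)cc21` gives 16%, compound 3 `CC1(C)CCOc2ccc(NC(=S)Nc3ccc(C(F)(F)F)cc3)cc21` gives 28%, and compound 2 `CCC1(CC)CC(CC)(CC)c2cc(NC(=O)Nc3ccc(C(F)(F)F)cc3)ccc2O1`, which carries a urea instead of a thiourea on a different, larger core, gives 86.2%. Compound 3 therefore stands second highest of the three numbers: clearly above compound 1 and far below compound 2. Going by the values given here, the only single-point step between measured compounds is a number 12 percentage points higher from compound 1 to compound 3 (beyond the scatter), a modest shift.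

Compound 4 `CC1(C)CCOc2ccc(NC(=S)Nc3ccc([N+](=O)[O-])cc3)cc21` has not yet been measured. It differs from compound 3 in one place: nitro in place of trifluoromethyl on an aromatic carbon. Among the compounds with values here, no measured pair covers this particular exchange; the only related evidence is the modest step between compound 1 and compound 3, which suggests that swapping the group on this ring changes the number by a small amount. For compound 4 the expected step in this assay is therefore small, a number 4 percentage points higher from compound 3 to compound 4 (within the scatter), in either direction or none beyond the scatter. Compound 4 is expected to give about 32%, with a likely range from 12% to 55%.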

Compound 4, percent growth inhibition at one concentration: 19%
Compound 4: middle estimate off by 13 percentage points, on the high side; the range from low to high includes it.
By their numbers in this assay, from the lowest: compounds 1, 4 and 3 (each within the scatter of the next, the first and the last beyond it); then compound 2.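

In this assay, nitro is a third group at this position on the aromatic ring, and its exchange for trifluoromethyl gives a number 9 percentage points lower from compound 3 to compound 4 (within the scatter), while its exchange for trifluoromethoxy gives a number 3 percentage points higher from compound 1 to compound 4 (within the scatter), so compound 4 cannot be told apart from either of the other two thioureas on this core. Across these three groups, the only step beyond the scatter remains the one between the two fluorinated groups (a number 12 percentage points higher from compound 1 to compound 3 (beyond the scatter)), and all three steps are small. Nothing measured here gives a reason for these numbers.

Going by these compounds, whether an amine or a carboxylic acid at this position would give a larger step remains open. The compounds shown also leave open what exchanging the thiourea for a urea does on a single core, since compound 2 differs from these compounds in more than one place.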